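Cyano to cyanoethenyl on the dimethylphenyl of a diarylpyrimidine

The source may hold more compounds than are shown below. What is called first, only, known or untested is meant among the compounds shown, and "the series" means these compounds.

Measured compounds:
compound 1 `C=CC(=O)N1CCN(Cc2ccc(Nc3nccc(Oc4c(C)cc(/C=C/C#N)cc4C)n3)cc2)CC1`, 5210 nM
compound 2 `Cc1cc(C#N)cc(C)c1Oc1ccnc(Nc2ccc(CN3CCN(S(=O)(=O)C4CC4)CC3)cc2)n1`, 4430 nM

In an ADME assay on MT4 cells (Homo sapiens) for cytotoxicity, read by MTT assay (on this read-out higher numbers stand for lower toxicity in this test and lower numbers for higher toxicity in this test), compound 2 gives 4430 nM, the lowest of the two numbers, while compound 1 gives 5210 nM, a gap that lies within the scatter. Compound 3 `Cc1cc(/C=C/C#N)cc(C)c1Oc1ccnc(Nc2ccc(CN3CCN(S(=O)(=O)C4CC4)CC3)cc2)n1` differs from compound 2 by 2-cyanoethenyl in place of cyano on an aromatic carbon. Going by the values given here, no measured pair isolates this change; compound 1 carries the cyanoethenyl but also a different piperazine substituent. A small step is expected, if anything towards a lower number, and likely within the scatter. Compound 3 is estimated at 3500 nM (range 1200 nM to 10000 nM), an expected step of a 1.3-fold lower number from compound 2 to compound 3 (0.10 log units; within the scatter).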

Compound 3, half-maximal cytotoxic concentration: 4350 nM
Estimate against measurement, compound 3: 1.2-fold (0.09 log units) below, within the range that was stated.
By their numbers in this assay, from the lowest: compounds 3, 2 and 1 (each within the scatter of the next).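

In this assay, the step from cyano to 2-cyanoethenyl on this aromatic carbon can now be read on its own, and it lies within the scatter (a 1.0-fold lower number from compound 2 to compound 3 (0.01 log units; within the scatter)). Compound 3 also isolates cyclopropylsulfonyl in place of vinylcarbonyl on the amine nitrogen in a ring, a step that is likewise within the scatter (a 1.2-fold lower number from compound 1 to compound 3 (0.08 log units; within the scatter)). Nothing available explains either result.

Going by these compounds, whether an amine, a carboxylic acid or a longer chain at this aromatic carbon would give a step beyond the scatter remains open. On these data alone, it is also open whether the change from cyano to 2-cyanoethenyl reads the same with vinylcarbonyl on the ring nitrogen.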